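This account rests on a few compounds, and the source may have more. Where it says the series, first, only, none or still open, it means among the compounds named here.

Measured so far:
Compound 1 `COc1cc(C(=O)c2sc(-c3cccc([N+](=O)[O-])c3)cc2N)cc(OC)c1OC`: 17 nM
Compound 2 `COc1cc(C(=O)c2sc(-c3ccccc3)cc2N)cc(OC)c1OC`: 13 nM
Compound 3 `COc1cc(C(=O)c2sc(-c3ccc(C)cc3)cc2N)cc(OC)c1OC`: 16 nM

In a functional assay on FM3A cells (Mus musculus) for antiproliferative activity (on this read-out lower numbers stand for stronger inhibition and higher numbers for weaker inhibition), compound 1 gives the highest of the three numbers, yet its distance to compound 2 and to compound 3 is within the usual scatter, so the three compounds cannot be told apart on these numbers. Compound 4 `CCOc1ccc(-c2cc(N)c(C(=O)c3cc(OC)c(OC)c(OC)c3)s2)cc1` is not yet measured; it differs from compound 1 in one place: 4-ethoxyphenyl in place of 3-nitrophenyl on an aromatic carbon. Among the compounds with values here, two measured steps bear on this change, since each also swaps the group attached at that aromatic carbon: a 1.3-fold lower number from compound 1 to compound 2 (0.12 log units; within the scatter) and a 1.1-fold lower number from compound 1 to compound 3 (0.03 log units; within the scatter). Both stayed within the scatter, so no step beyond the scatter is expected here either. Compound 4 is therefore expected to give about 18 nM, with a likely range from 8 nM to 45 nM. The expected step is a 1.1-fold higher number from compound 1 to compound 4 (0.02 log units; within the scatter).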

Compound 4, half-maximal inhibitory concentration: 510 nM
For compound 4 the middle estimate is 28-fold (1.45 log units) below the measured one; the whole stated range lies below it.
By their numbers in this assay, from the lowest: compounds 2, 3 and 1 (each within the scatter of the next); then compound 4.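

In this assay the 3-nitrophenyl, phenyl and 4-methylphenyl groups could not be told apart at this position, but 4-ethoxyphenyl stands clearly apart, with a 30-fold higher number from compound 1 to compound 4 (1.48 log units; beyond the scatter) and a 32-fold higher number from compound 3 to compound 4 (1.50 log units; beyond the scatter) and also a 39-fold higher number from compound 2 to compound 4 (1.59 log units; beyond the scatter). So this position does not accept every group equally, and replacing methyl with ethoxy on the phenyl ring is enough for a large loss of activity. Nothing shown here gives a reason for this loss. From the compounds shown here alone, it remains open whether the loss follows the added oxygen or the longer chain, which a methoxy or a propyl group in the same place could separate.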